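The compounds below may be only part of what the source reports. "The series", "measured", "known", "first", "only" and "open" are said of these compounds alone.

Measured compounds:
Compound 1 `CCCC[C@@H](C)C[C@@H](C)C(=O)N(C)[C@@H](C=C(C)C)C(=O)N[C@H](C(=O)N(C)[C@H](C(=O)N1CCC[C@H]1C(=O)N1C(=O)C=C[C@@H]1C)C(C)C)[C@@H](C)OC(C)=O` gives 1000 nM in a functional assay on NCI-H460 cells (Homo sapiens) for cytotoxicity, read by MTT assay, with a stated time of 48 h; a lower number here means a stronger inhibitor, a higher number a weaker inhibitor.
Compound 2 `CCCC[C@@H](C)C[C@@H](C)C(=O)N(C)[C@@H](C=C(C)C)C(=O)N[C@H](C(=O)N(C)[C@H](C(=O)N1C[C@@H](O)C[C@H]1C(=O)N1C(=O)C=C[C@@H]1C)C(C)C)[C@@H](C)OC(C)=O` gives 37 nM in this assay.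
Compound 3 `CCCC[C@@H](C)C[C@@H](C)C(=O)N(C)[C@@H](CC(C)C)C(=O)N[C@H](C(=O)N(C)[C@H](C(=O)N1CCC[C@H]1C(=O)N1C(=O)C=C[C@@H]1C)C(C)C)[C@@H](C)O` gives 650 nM in this assay.

Compound 2 differs from compound 1 by a single change, (hydroxy in place of hydrogen on a saturated ring carbon), and the step of a 27-fold lower number from compound 1 to compound 2 (1.43 log units; beyond the scatter) is a large one. Compound 3 shares with compound 1 a core that differs from it in more than one place; the difference between the two cores is not broken down here. In this assay compound 3 gives 650 nM, and compound 1 gives 1000 nM, so the two values lie close together.

Compound 4 `CCCC[C@@H](C)C[C@@H](C)C(=O)N(C)[C@@H](CC(C)C)C(=O)N[C@H](C(=O)N(C)[C@H](C(=O)N1C[C@@H](O)C[C@H]1C(=O)N1C(=O)C=C[C@@H]1C)C(C)C)[C@@H](C)O` is not yet measured. It stands to compound 3 as compound 2 stands to compound 1: the change is hydroxy in place of hydrogen on a saturated ring carbon, and the place around it is described in the same words in both cases, so it is the same change made on the core of compound 3. It occurs twice among the compounds shown, measured only once.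

The expectation for compound 4 rests on that one measured instance, because a 27-fold lower number from compound 1 to compound 2 (1.43 log units; beyond the scatter) is the only record of what this change does. Starting from compound 3, the expected step is a 26-fold lower number from compound 3 to compound 4 (1.41 log units; beyond the scatter), set beside the earlier one in size. Compound 4 is therefore estimated at 25 nM in this assay, with a range from 8 nM to 90 nM, the width reflecting that the core of compound 3 is not the core on which the change was measured.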

Compound 4, half-maximal inhibitory concentration: 75 nM
Compound 4: middle estimate off by 3.0-fold (0.48 log units), on the low side; the measured number falls inside the stated range.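

In this assay, hydroxy in place of hydrogen on a saturated ring carbon also lowers the number on the core of compound 3, with an 8.7-fold lower number from compound 3 to compound 4 (0.94 log units; beyond the scatter) on that core, so the direction of the step seen on the core of compound 1 carries over. The size does not carry over intact, and the two steps differ by more than the usual scatter: the same change on two cores in this assay, a 27-fold lower number (1.43 log units; beyond the scatter) from compound 1 to compound 2 and an 8.7-fold lower number (0.94 log units; beyond the scatter) from compound 3 to compound 4, 3.1-fold (0.49 log units) apart, beyond the scatter of two such steps. This shows that, on these two cores, the change keeps its direction but not its full size; it does not show what sets the size, which of the differences between the two cores matters, or how the step would behave on any further core.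

The compounds shown leave open what other groups would do on that saturated ring carbon, two ring bonds from the ring nitrogen, such as a methoxy group, a fluorine atom or an amine, as only hydrogen and hydroxy appear there. They also leave open how the step would look on a core that carries just one of the differences between the core of compound 1 and the core of compound 3.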